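The source may report more compounds than this note shows. Statements on the series, on what has been measured and on what is new or still open speak of the compounds shown alone.

Of the compounds shown here, three have been measured and a fourth awaits measurement in a functional assay on A549 cells (Homo sapiens) for cytotoxicity, read by MTT assay, with a stated time of 24 h; a lower number here means a stronger inhibitor, a higher number a weaker inhibitor. Compound 1, `Cn1nc(-c2nnc(SCc3c(F)cccc3F)o2)cc1-c1ccc(C(F)(F)F)cc1`, gives in this assay 38000 nM. Compound 2, `Cn1nc(-c2nnc(SCCOc3ccccc3F)o2)cc1-c1ccc(C(F)(F)F)cc1`, differs from compound 1 by one change, ((2-fluorophenoxy)methyl in place of 2,6-difluorophenyl on a saturated chain carbon bound to a sulfur), and in this assay compound 2 gives 48100 nM. The step this change made is a 1.3-fold higher number from compound 1 to compound 2 (0.10 log units; within the scatter), so the two values cannot be told apart by this measurement.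

Compound 3, `Cn1nc(-c2ccc(C(F)(F)F)cc2)cc1-c1nnc(SCc2c(F)cccc2F)o1`, is made of the same atoms as compound 1 joined differently; the difference between the two cores is not broken down here. In this assay compound 3 gives 72200 nM, a value that lies within the scatter of both compound 1 and compound 2, so no order among the three can be claimed.

Compound 4, `Cn1nc(-c2ccc(C(F)(F)F)cc2)cc1-c1nnc(SCCOc2ccccc2F)o1`, has not yet been measured. It differs from compound 3 by (2-fluorophenoxy)methyl in place of 2,6-difluorophenyl on a saturated chain carbon bound to a sulfur, which is the same change, at the same place, that turned compound 1 into compound 2. Because that change produced a 1.3-fold higher number from compound 1 to compound 2 (0.10 log units; within the scatter), the expectation is that it will again move the number little, so compound 4 is expected to come out near compound 3, with the estimated step of a 1.2-fold higher number from compound 3 to compound 4 (0.10 log units; within the scatter). For compound 4 the estimate is 90000 nM, expected to fall between 45000 nM and 180000 nM; this rests on a single earlier instance of the change and so remains uncertain.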

Compound 4, half-maximal inhibitory concentration: 68100 nM
Compound 4: middle estimate off by 1.3-fold (0.12 log units), on the high side; measured number inside the range.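

In this assay, replacing the 2,6-difluorobenzyl group of compound 3 with the 2-(2-fluorophenoxy)ethyl group gives a 1.1-fold lower number from compound 3 to compound 4 (0.03 log units; within the scatter) and so leaves the two compounds indistinguishable by this measurement. Set beside the earlier case, the same change behaves alike on both cores, with no difference that this measurement can resolve: the same change on two cores in this assay, a 1.3-fold higher number (0.10 log units; within the scatter) from compound 1 to compound 2 and a 1.1-fold lower number (0.03 log units; within the scatter) from compound 3 to compound 4, 1.3-fold (0.13 log units) apart, within the scatter of two such steps. For the compounds shown here, this shows that swapping one of these two groups for the other can be carried from one core to the other here without a readable shift in the number, but it rests on only two pairs of compounds, and neither step rises above the scatter, so what repeats is the absence of a measurable effect rather than an effect of real size.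

The compounds shown leave open whether the result would hold if the group attached through the sulfur carried an amine or a carboxylic acid, or if a longer chain took the place of the 2-(2-fluorophenoxy)ethyl group. They also leave open what would happen if a nitrile replaced the trifluoromethyl group, and whether the change would stay as silent on any core beyond these two.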